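Adding a Chloro Group to a Salicylanilide Cytotoxic Scaffold

This account rests on a few compounds, and the source may have more. Where it says the series, first, only, none or still open, it means among the compounds named here.

Three compounds have been measured:
compound 1 `O=C(Nc1cc(C(F)(F)F)cc(C(F)(F)F)c1)c1ccc(-c2ccccc2)cc1O` gives 860 nM in a functional assay on KG-1 cells (Homo sapiens) for cytotoxicity, read by luminescence and CellTiter-Glo, with a stated time of 3 days; a lower number here means a stronger inhibitor, a higher number a weaker inhibitor;
compound 2 `N#Cc1ccc(NC(=O)c2cc(Cl)ccc2O)cc1` gives 1860 nM in this assay;
compound 3 `N#Cc1ccc(NC(=O)c2ccccc2O)cc1` gives 5370 nM in this assay.

Compound 4 `O=C(Nc1cc(C(F)(F)F)cc(C(F)(F)F)c1)c1cc(Cl)c(-c2ccccc2)cc1O` has not yet been measured. It differs from compound 1 by one change: chloro in place of hydrogen on an aromatic carbon The same kind of change has already been made once, in going from compound 3 to compound 2: chloro in place of hydrogen on an aromatic carbon That step was a 2.9-fold lower number from compound 3 to compound 2 (0.46 log units; beyond the scatter). The two places are not identical in their surroundings: in compound 4 the new chloro group sits ortho to a phenyl group (6 heavy atoms), a neighbour that compound 2 lacks, while in both cases it is meta to a large group and para to a hydroxy group. The difference between the core of compound 1 and the core of compound 3 is not broken down here; compound 1 simply shows the lowest number of the three.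

Within the data shown here, on the strength of the one earlier step, compound 4 is expected to land at 400 nM, within 150 nM to 1000 nM, meaning an estimated step of a 2.2-fold lower number from compound 1 to compound 4 (0.33 log units; beyond the scatter), because a change of the same kind gave a 2.9-fold lower number from compound 3 to compound 2 (0.46 log units; beyond the scatter).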

Compound 4, half-maximal inhibitory concentration: 430 nM
The estimate for compound 4 lay 1.1-fold (0.03 log units) below the measured number, within the range that was stated.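

Chloro in place of hydrogen on an aromatic carbon gave a 2.0-fold lower number from compound 1 to compound 4 (0.30 log units; within the scatter) in this assay, so taken alone this step cannot be read as a real change. Set beside the earlier step, it points the same way and the two sizes do not separate, so on these two cores the change carries over with a similar size: the same change on two cores in this assay, a 2.9-fold lower number (0.46 log units; beyond the scatter) from compound 3 to compound 2 and a 2.0-fold lower number (0.30 log units; within the scatter) from compound 1 to compound 4, 1.4-fold (0.16 log units) apart, within the scatter of two such steps

Among these compounds, this rests on only one pair for each core, and only in compound 4 is the chloro group ortho to a phenyl group, so it gives no general rule for the series and does not say why the numbers move. From the compounds shown here alone, it remains open whether a bromo group, a methyl group, a methoxy group or an amine in the same place would give a step like that of the chloro group. Going by these compounds, it is also open whether the chloro step would hold on further cores, or in any read-out other than this assay.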